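Oxane for thiane on the shared core: compound 4

The compounds below may be only part of what the source reports. "The series", "measured", "known", "first", "only" and "open" are said of these compounds alone.

Compound 1 `c1ccc2c(c1)CN[C@@H](CN(CCCCNCC1CCSCC1)[C@H]1CCCc3cccnc31)C2` gives 69.6 nM in a functional assay on cells for antagonist activity at C-X-C chemokine receptor type 4 (Homo sapiens), read by fluorescence and calcium flux, with stated times of 25 min and 90 s; on this read-out lower numbers stand for stronger inhibition and higher numbers for weaker inhibition.
Compound 2 `NCc1ccccc1CN(C[C@H]1Cc2ccccc2CN1)[C@H]1CCCc2cccnc21` gives 50.8 nM.
Compound 3 `C(=C/CN(C[C@H]1Cc2ccccc2CN1)[C@H]1CCCc2cccnc21)\CNC1CCOCC1` gives 15.5 nM.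

Compound 1 has the highest number of the three: a 1.4-fold lower number from compound 1 to compound 2 (0.14 log units; within the scatter), and a 4.5-fold lower number from compound 1 to compound 3 (0.65 log units; beyond the scatter). Between the other two, a 3.3-fold lower number from compound 2 to compound 3 (0.52 log units; beyond the scatter).

Compound 4 `CC(C)(CCN(C[C@H]1Cc2ccccc2CN1)[C@H]1CCCc2cccnc21)CNCC1CCOCC1` differs from compound 1 in one place: a group of 12 heavy atoms (10 carbon, 1 nitrogen, 1 oxygen; one six-membered non-aromatic ring with 1 hetero atom) in place of a group of 10 heavy atoms (8 carbon, 1 nitrogen, 1 sulfur; one six-membered non-aromatic ring with 1 hetero atom), on a saturated chain carbon, two bonds along the chain from an amine nitrogen. Among the compounds with values here, the one measured step that bears on this is a 4.5-fold lower number from compound 1 to compound 3 (0.65 log units; beyond the scatter), where a ring with oxygen likewise replaced the ring with sulfur, though on a different chain. The chain of compound 4 is not that of compound 3, so a smaller step in the same direction is expected in this assay. The expected step is a 2.0-fold lower number from compound 1 to compound 4 (0.30 log units; within the scatter). Compound 4 is estimated at 35 nM, with a range from 12 nM to 100 nM.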

Compound 4, half-maximal inhibitory concentration: 43.8 nM
Compound 4: the middle estimate sits 1.3-fold (0.10 log units) below what was measured, within the range that was stated.
By their numbers in this assay, from the lowest: compound 3; then compounds 4, 2 and 1 (each within the scatter of the next).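

In this assay, a 1.6-fold lower number from compound 1 to compound 4 (0.20 log units; within the scatter) shows that the group of 12 heavy atoms with its oxygen ring and the group of 10 heavy atoms with its sulfur ring are not separated at this place, on a saturated chain carbon, two bonds along the chain from an amine nitrogen. The oxygen-for-sulfur exchange therefore does not always carry the step beyond the scatter seen in a 4.5-fold lower number from compound 1 to compound 3 (0.65 log units; beyond the scatter). No supporting data bear on the reason for this difference.

The separate contributions of ring and chain remain unresolved, since the entering and leaving groups differ in both. As far as these compounds go, a piperidine ring or a longer chain at this place also remains open.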